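Swapping Furan-2-yl for Pyridin-3-yl on a Carbonyl Carbon

The source may report more compounds than this note shows. Statements on the series, on what has been measured and on what is new or still open speak of the compounds shown alone.

Going by the values given here, in a functional assay on HCT-15 cells (Homo sapiens) for antiproliferative activity (on this read-out lower numbers stand for stronger inhibition and higher numbers for weaker inhibition), compound 3 (`COc1ccc(S(=O)(=O)Oc2ccccc2NC(=O)c2ccco2)cc1`) gives 19 nM and compound 1 (`COc1ccc(S(=O)(=O)Oc2ccccc2NC(=O)c2ccncc2)cc1`) gives 89 nM so compound 3 holds the lowest actual number so far. Compound 2 (`COc1ccc(S(=O)(=O)Oc2ccccc2NC(=O)c2ccc(N(C)C)cc2)cc1`) stands at > 10000 nM and that is a limit of the assay, not a number.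

Compound 4 (`COc1ccc(S(=O)(=O)Oc2ccccc2NC(=O)c2cccnc2)cc1`) differs from compound 3 by carrying pyridin-3-yl in place of furan-2-yl on a carbonyl carbon. The closest guide is compound 1, which carries pyridin-4-yl at that place (a 4.7-fold lower number from compound 1 to compound 3 (0.67 log units; beyond the scatter)). Read backwards, that modest step suggests that leaving furan-2-yl for pyridin-3-yl may raise the number by a similar amount. The large step to compound 2 (an at least 110-fold higher number from compound 1 to compound 2 (2.05 log units; beyond the scatter)) brings in 4-(dimethylamino)phenyl, a much less similar group, so it carries less weight here. A modest rise is therefore expected (a 3.9-fold higher number from compound 3 to compound 4 (0.60 log units; beyond the scatter)). In this assay compound 4 is estimated at 75 nM with 20 nM to 350 nM as the expected range.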

Compound 4, half-maximal inhibitory concentration: > 3000 nM
Compound 4: no number, only a limit (the forecaster's own chance of this, stated with the estimate: 5%); middle value at least 40-fold (1.60 log units) away from the limit.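

In this assay, the result shows that a pyridine ring at this carbonyl carbon is not enough in itself, since the attachment point of that ring decides the outcome: pyridin-3-yl in place of pyridin-4-yl gives an at least 33-fold higher number from compound 1 to compound 4 (1.52 log units; beyond the scatter), and pyridin-3-yl in place of furan-2-yl gives an at least 150-fold higher number from compound 3 to compound 4 (2.19 log units; beyond the scatter). Compound 4 has no actual number, only a limit of the assay: the limit of > 3000 nM in this assay, at which 1 of the 4 values shown sits. Compound 2 also stands at a limit, so the step between compound 2 and compound 4 cannot be read.

What lies behind the gap between the two pyridinyl groups stays open, and the compounds shown give no cause for it. A pyridin-2-yl or thiophen-2-yl group on the same carbonyl carbon would test whether the sharp loss belongs to pyridin-3-yl alone or extends to other rings.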